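The compounds below may be only part of what the source reports. "The series", "measured", "known", "first", "only" and "open" are said of these compounds alone.

Measured so far in a functional assay on PC-3 cells (Homo sapiens) for cytotoxicity, read by MTT assay, with a stated time of 48 h, tested at 25 uM; on this read-out lower numbers stand for a weaker effect and higher numbers for a stronger effect at the one concentration tested:
compound 1 `O=C(c1ccc(O)cc1O)[C@H]1[C@H](c2ccccc2)[C@H](C(=O)c2ccc(O)cc2O)[C@H]1c1ccccc1` — 88%
compound 2 `O=C(c1ccc(O)cc1O)[C@H]1[C@H](c2ccccc2)[C@H](C(=O)c2ccc(O)cc2O)[C@@H]1c1ccccc1` — 57.9%

Compound 2 gives 57.9% in this assay, the lower of the two numbers; compound 1 gives 88%. For the measured compounds named here, the one measured step, a number 30.1 percentage points lower from compound 1 to compound 2 (beyond the scatter), is large and rests on configuration alone, because the fact that compounds 1 and 2 differ only in the configuration as drawn is the only difference between the pair.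

Compound 3 `O=C(c1ccc(O)cc1O)[C@H]1[C@H](c2ccccc2)[C@@H](C(=O)c2ccc(O)cc2O)[C@@H]1c1ccccc1` is the next stereoisomer. The change from compound 2: the two compounds have the same atoms and bonds and differ only in configuration as drawn: 3 of 4 stereo elements differ; a stereocentre at a saturated ring carbon is drawn S in compound 2 and r in compound 3; a stereocentre at a saturated ring carbon is drawn s in compound 2 and r in compound 3; a stereocentre at a saturated ring carbon is drawn R in compound 2 and r in compound 3

Going by the values given here, no step of this kind has been measured: the known step swaps two stereo elements, this one swaps three, so it bears on the question only as a sign that configuration alone can shift this assay by a large amount in either direction. The direction for compound 3 cannot be read from compound 1 and compound 2. Since the measured pair spans a wide band, compound 3 is estimated to land inside that band, at 68%, within 38% to 92%, which is expected to mean a step of a number 10.1 percentage points higher from compound 2 to compound 3 (beyond the scatter).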

Compound 3, a percentage reported as activity, at one concentration (the size of the read-out at that concentration, not a potency): 76.7%
Compound 3: the middle estimate sits 8.7 percentage points below what was measured; low and high end bracket the measured number.
By their numbers in this assay, from the lowest: compound 2; then compound 3; then compound 1.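

In this assay, the configuration effect now has a second measured size, and the change of three stereo elements raises the read-out rather than lowering it, with a step of a number 18.8 percentage points higher from compound 2 to compound 3 (beyond the scatter); this shift rests on configuration alone: the fact that compounds 2 and 3 differ only in the configuration as drawn

The new compound also gives the first mirror-image comparison in the series, and inverting all four stereocentres gives a step of a number 11.3 percentage points lower from compound 1 to compound 3 (beyond the scatter), so the two mirror images are not equivalent in this cell read-out at the one concentration tested: the fact that compounds 1 and 3 differ only in the configuration as drawn

Among these three compounds, the size of a step does not grow with the number of stereo elements changed, since the change of two stereo elements gave the largest step, a number 30.1 percentage points lower from compound 1 to compound 2 (beyond the scatter).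

Still open, as far as these compounds go, is whether this order of the stereoisomers survives a change of substituent, for example an amine or a carboxylic acid in place of the hydroxyl groups. These percentages give the size of the effect at the one concentration tested and leave open whether the three compounds would show a stronger or weaker effect in the same order at other concentrations.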